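Swapping 4-(methoxycarbonyl)phenyl for benzyl

The source may hold more compounds than are shown below. What is called first, only, known or untested is meant among the compounds shown, and "the series" means these compounds.

In an ADME assay on S9 fraction from liver (Rattus norvegicus) for metabolic stability, read by LC-MS, using NADPH, with a stated time of 30 min (a higher number here means that more of the compound is left, a lower number that less of the compound is left), compound 2 `CCCCCCCCc1ccc(OCC(=O)Cn2nnc(-c3ccc(C(=O)OC)cc3)n2)cc1` stands highest of three measured compounds at 64%. Compound 1 `CCCCCCCCc1ccc(OCC(=O)Cn2nnc(-c3ccccc3)n2)cc1` gives 33%, and compound 3 `CCCCCCCCc1ccc(OCC(=O)Cn2nnc(-c3ccccn3)n2)cc1` gives 30%. Compound 4 `CCCCCCCCc1ccc(OCC(=O)Cn2nnc(Cc3ccccc3)n2)cc1` has benzyl in place of the 4-(methoxycarbonyl)phenyl of compound 2 on an aromatic carbon (benzyl in place of 4-(methoxycarbonyl)phenyl on an aromatic carbon). Among the compounds with values here, three measured steps bear on this change. Putting methoxycarbonyl in place of hydrogen gave a number 31 percentage points higher from compound 1 to compound 2 (beyond the scatter), while exchanging phenyl for pyridin-2-yl gave a number 3 percentage points lower from compound 1 to compound 3 (within the scatter). Since a number 34 percentage points lower from compound 2 to compound 3 (beyond the scatter) came with the loss of methoxycarbonyl, and benzyl carries none either, a large fall is expected, with an estimated step of a number 32 percentage points lower from compound 2 to compound 4 (beyond the scatter). Within the data shown here, no measured compound carries benzyl, so the range stays wide. Compound 4 is expected at 32%, within 15% to 50%.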

Compound 4, percent of the compound remaining: < 5%
Compound 4 was reported as a limit (the forecaster's own chance of this, stated with the estimate: 2%); at least 27 percentage points between middle value and limit.
By their numbers in this assay, from the lowest: compounds 3 and 1 (each within the scatter of the next); then compound 2. At a limit, below all of these: compound 4.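

In this assay compound 4 stands at a limit and not at a number: the limit of < 5% in this assay, at which 1 of the 4 values shown sits.

Benzyl on this aromatic carbon does not behave like the groups seen before, with a number at least 59 percentage points lower from compound 2 to compound 4 (beyond the scatter), a number at least 25 percentage points lower from compound 3 to compound 4 (beyond the scatter) and a number at least 28 percentage points lower from compound 1 to compound 4 (beyond the scatter). Pyridin-2-yl in place of phenyl had left the number within the scatter, so the earlier compounds gave no sign that this position could take the number so low.

Going by these compounds, whether methoxycarbonyl on the ring of benzyl would raise the number stays open. So does whether a carboxylic acid in place of that ester would keep the high number of compound 2.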